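Swapping the Benzamide Ring: Fluorine Out, Two Chlorines In

The source may report more compounds than this note shows. Statements on the series, on what has been measured and on what is new or still open speak of the compounds shown alone.

Of the compounds shown here, two built on the same core have been tested in a functional assay on HeLa cells (Homo sapiens) for inhibition, read by MTT assay, with a stated time of 72 h; a lower number here means a stronger inhibitor, a higher number a weaker inhibitor. Compound 1, `CN(C(=O)NC(=O)c1cccc(C(F)(F)F)c1)c1nc(C(F)(F)F)c(C(=O)N/N=C/c2cccc(C(F)(F)F)c2)s1`, gives 4.81 ug/mL in this assay. Compound 2, `CN(C(=O)NC(=O)c1ccccc1F)c1nc(C(F)(F)F)c(C(=O)N/N=C/c2ccc(C(F)(F)F)cc2)s1`, gives 3.97 ug/mL in this assay. Compound 2 shows the lower of the two numbers, but the gap to compound 1 falls within the scatter of repeated measurements, so the two cannot be told apart on these data.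

Compound 3, `CN(C(=O)NC(=O)c1ccc(Cl)cc1Cl)c1nc(C(F)(F)F)c(C(=O)N/N=C/c2ccc(C(F)(F)F)cc2)s1`, has not yet been measured. It differs from compound 2 in one place: 2,4-dichlorophenyl in place of 2-fluorophenyl on a carbonyl carbon. For the measured compounds named here, no pair of measured compounds with a single difference is available, so the size of such a step in this assay is unknown. Going by the values given here, the one comparison that exists, between compound 1 and compound 2, spans a change in the same acyl part and in the hydrazone part at once, and yields no separation beyond the scatter.

The step from compound 2 to compound 3 is therefore expected to be small, a 1.0-fold lower number from compound 2 to compound 3 (0.02 log units; within the scatter), likely not beyond the scatter in either direction. Compound 3 is estimated to give 3.8 ug/mL in this assay, with a plausible range from 1.6 ug/mL to 9 ug/mL.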

Compound 3, half-maximal inhibitory concentration: 7.99 ug/mL
Compound 3: middle estimate off by 2.1-fold (0.32 log units), on the low side; low and high end bracket the measured number.
By their numbers in this assay, from the lowest: compounds 2, 1 and 3 (each within the scatter of the next).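

For the compounds shown here, this is the first pair that differs in one place only, and in this assay it gives a 2.0-fold higher number from compound 2 to compound 3 (0.30 log units; within the scatter) for the swap on the carbonyl carbon. With the rest of compound 2 kept, 2,4-dichlorophenyl can therefore stand in place of 2-fluorophenyl at this position without the two compounds separating from each other, although the step lies right at the edge of what repeated measurements would scatter by. No measurement at hand speaks to what lies behind this step.

A single step at a single position cannot show whether any other group here would separate from these two, such as a plain phenyl ring, a phenyl ring carrying an amine or a carboxylic acid, or a longer alkyl chain in place of the ring. It also leaves open whether the same swap from 2-fluorophenyl to 2,4-dichlorophenyl would give a step of similar size if the hydrazone part of the molecule were different.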